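The source may report more compounds than this note shows. Statements on the series, on what has been measured and on what is new or still open speak of the compounds shown alone.

Measured so far in an ADME assay on MDBK cells (Bos taurus) for cytotoxicity, read by MTT assay; on this read-out lower numbers stand for higher toxicity in this test and higher numbers for lower toxicity in this test:
Compound 1 `CC1CCCCC1N(CCCCCCN1C[C@H](O)[C@@H](O)[C@H](O)[C@H]1CO)C(=O)OC(C)(C)C` gives 250000 nM.
Compound 2 `CC1CCCCC1N(CCCCCCN1C[C@H](O)[C@@H](O)[C@H](O)[C@H]1CO)C(=O)C(C)(C)C` gives > 500000 nM, a limit of the assay.
Compound 3 `CC(C)(C)C(=O)N(CCCCCCN1C[C@H](O)[C@@H](O)[C@H](O)[C@H]1CO)C1CCCCC1` gives > 500000 nM, also a limit of the assay.

Compound 3 thus sits at the limit of > 500000 nM in this assay, at which 2 of the 3 values shown sit, so its true number is not read. Compound 4 `CC(C)(C)CC(=O)N(CCCCCCN1C[C@H](O)[C@@H](O)[C@H](O)[C@H]1CO)C1CCCCC1` differs from compound 3 by neopentyl in place of tert-butyl on a carbonyl carbon. Among the measured compounds shown here, the one measured change at that same carbonyl carbon is an at least 2.0-fold higher number from compound 1 to compound 2 (0.30 log units; that floor lies within the scatter), a change whose floor the scatter would cover. The change from compound 2 to compound 3 reads as a step that the two limits leave unreadable from compound 2 to compound 3, since both numbers are limits. For the measured compounds named here, no measured step on this series shows movement beyond the scatter, and the change from tert-butyl to neopentyl adds one carbon on the same carbonyl carbon. Compound 4 is therefore expected to show no step beyond the scatter in this assay, that is a number no higher from compound 3 to compound 4 (the limit leaves the size open). For compound 4 the estimate in this assay is 500000 nM, expected to fall between 250000 nM and 1000000 nM, most likely again reported only as a limit.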

Compound 4, half-maximal cytotoxic concentration: > 500000 nM
Compound 4 gave a limit, no number; the forecaster's own chance of this, stated with the estimate: 70%; the middle value sits exactly at the limit.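

In this assay compound 4 gives > 500000 nM, a limit of the assay. Among the compounds shown here, compound 3 also stands at a limit, so no step from compound 3 to compound 4 can be read. The compounds shown leave open whether neopentyl in place of tert-butyl on a carbonyl carbon changes this read-out at all.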